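Notes on a quinone series: amine swap on the enone carbon

This account rests on a few compounds, and the source may have more. Where it says the series, first, only, none or still open, it means among the compounds named here.

Among the measured compounds shown here, compound 1 `O=C1C=C(Nc2ccccc2F)C(=O)c2c1nc1n2[C@H]2OC[C@@H](O)[C@H]2OC1` is the one compound with a number in a functional assay on MCF7 cells (Homo sapiens) for inhibition, read by sulforhodamine B assay (a higher number here means a weaker inhibitor, a lower number a stronger inhibitor), where compound 1 gives 3640 nM. Compound 2 `CCOc1ccc(NC2=CC(=O)c3c(nc4n3[C@H]3OC[C@@H](O)[C@H]3OC4)C2=O)cc1` reaches only a limit in this assay, > 4000 nM, which marks the edge of the measurement and is not a number (the limit of > 4000 nM in this assay, at which 1 of the 2 values shown sits). Compound 3 `O=C1C=C(N2CCCCC2)C(=O)c2c1nc1n2[C@H]2OC[C@@H](O)[C@H]2OC1` differs from compound 1 in one place: piperidin-1-yl in place of (2-fluorophenyl)amino on a double-bonded ring carbon. For the measured compounds named here, no measured pair shows the size of such a change. A step within the scatter, or one toward a weaker inhibitor, is expected for a 1.5-fold higher number from compound 1 to compound 3 (0.18 log units; within the scatter). For compound 3 the estimate in this assay is 5500 nM, with a range from 2000 nM to 20000 nM, and a limit is a likely outcome.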

Compound 3, half-maximal inhibitory concentration: > 8000 nM
Compound 3 was reported as a limit; the forecaster's own chance of this, stated with the estimate: 55%; middle value at least 1.4-fold (0.16 log units) away from the limit.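

At the double-bonded ring carbon, piperidin-1-yl in place of (2-fluorophenyl)amino gives an at least 2.1-fold higher number from compound 1 to compound 3 (0.34 log units; beyond the scatter) in this assay, the first size read for a change at this position. The reading for compound 3 is a limit and not a number: the limit of > 8000 nM in this assay, at which 1 of the 3 values shown sits. On these data alone, the true size of the step therefore stays open on its upper side.

The compounds shown do not separate the aromatic ring from the hydrogen-bond donor, as piperidin-1-yl has neither. A cyclohexylamino group on this carbon, which keeps the donor on a non-aromatic ring, would part the two.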